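The source may hold more compounds than are shown below. What is called first, only, known or untested is meant among the compounds shown, and "the series" means these compounds.

Working notes on the series. In an ADME assay on BJ cells (Homo sapiens) for cytotoxicity, with a stated time of 72 h (on this read-out higher numbers stand for an effect only at larger amounts of compound and lower numbers for an effect already at smaller amounts), compound 1 (`Cc1ccc(-c2nc3ccccc3s2)cc1NC(=O)c1cc([N+](=O)[O-])c(N2CCC(C(=O)O)CC2)cc1Cl`) gives > 25000 nM as a limit of the assay. Compound 2 (`Cc1ccc(-c2nc3ccccc3s2)cc1NC(=O)c1cc([N+](=O)[O-])c(N(C)C)cc1Cl`) gives > 25000 nM as a limit too. Compound 3 (`COC(=O)C1CCN(c2cc(Cl)c(C(=O)Nc3cc(-c4nc5ccccc5s4)ccc3C)cc2[N+](=O)[O-])CC1`) gives > 25000 nM as a limit as well, so it has no number of its own. All three sit at one shared limit (the limit of > 25000 nM in this assay, at which 3 of the 3 values shown sit).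

Next comes compound 4 (`Cc1ccc(-c2nc3ccccc3s2)cc1NC(=O)c1cc([N+](=O)[O-])c(N2CCCCC2)cc1Cl`), which carries hydrogen in place of methoxycarbonyl on a saturated ring carbon. Among the measured compounds shown here, three measured steps bear on it: a step that the two limits leave unreadable from compound 2 to compound 3 and a step that the two limits leave unreadable from compound 1 to compound 3 and a step that the two limits leave unreadable from compound 1 to compound 2. None of them has a readable size, so no measured size carries over to this change.

No step beyond the scatter is expected in this assay and no direction is expected either. This expectation rests on compound 3 with its limit of > 25000 nM as the reference. The estimated step (a number no higher from compound 3 to compound 4 (the limit leaves the size open)) therefore carries no expected direction. Compound 4 is estimated at 25000 nM with an expected range from 12000 nM to 40000 nM and will most likely be reported only as a limit.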

Compound 4, half-maximal effective concentration: > 25000 nM
Compound 4 gave a limit, no number; the forecaster's own chance of this, stated with the estimate: 85%; the middle value sits exactly at the limit.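

Compound 4 gives no readable step against compound 1, compound 2 or compound 3, since all four values are limits and not numbers: the limit of > 25000 nM in this assay, at which 4 of the 4 values shown sit.

The compounds shown leave open how far apart these four lie, and whether any of these changes shifts the read-out at all.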